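The source may report more compounds than this note shows. Statements on the series, on what has been measured and on what is new or still open speak of the compounds shown alone.

In a functional assay on HTB-54 cells (Homo sapiens) for cytotoxicity, read by MTT assay, with a stated time of 72 h (on this read-out higher numbers stand for weaker inhibition of growth and lower numbers for stronger inhibition of growth), compound 2 `CSc1nc(NCc2ccc([Se]C)cc2)c2ccccc2n1` gives 57000 nM, the highest number of the three measured compounds; compound 1 `CCCCCSc1nc(NCc2ccc([Se]C)cc2)c2ccccc2n1` gives 19800 nM and compound 3 `CCCCC[Se]c1nc(N)c2cccnc2n1` gives 8780 nM. Within the data shown here, the one step between close neighbours, a 2.9-fold higher number from compound 1 to compound 2 (0.46 log units; beyond the scatter), concerns the chain on the sulfur, not the ring substituent. Compound 4 `COc1ccc(CNc2nc(SC)nc3ccccc23)cc1` differs from compound 2 by a group of 2 heavy atoms (1 carbon, 1 oxygen; no ring) in place of a group of 2 heavy atoms (1 carbon, 1 selenium; no ring), on an aromatic carbon, para to a large group. Among the measured compounds shown here, no measured step touches that ring position, and all three measured compounds carry the selenium group, so there is no guide for exchanging it; the change is expected to move this assay by little, if anything, beyond the scatter. Compound 4 is therefore estimated at 60000 nM, within 20000 nM to 180000 nM, a step of a 1.1-fold higher number from compound 2 to compound 4 (0.02 log units; within the scatter).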

Compound 4, concentration for 50% growth inhibition: 93700 nM
Beside the measured number, compound 4's estimate is 1.6-fold (0.19 log units) below it, and the stated range covers the measured number.
By their numbers in this assay, from the lowest: compound 3; then compound 1; then compounds 2 and 4 (each within the scatter of the next).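

In this assay, among these compounds, the exchange of the selenium-bearing group for methoxy, on an aromatic carbon para to a large group, gives the first measured step at this position: a 1.6-fold higher number from compound 2 to compound 4 (0.22 log units; within the scatter). On the core of compound 2, then, selenium at this position is not required for a number of this size, since the step cannot be told apart from the scatter. Nothing available explains this result.

Going by these compounds, whether the exchange would behave the same way on the longer sulfur chain of compound 1 remains open. So does the effect of an amine, a chlorine atom or a carboxylic acid at this ring position.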